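From Sulfonyl to Piperidinylmethyl on the Pendant Aromatic Ring

The source may report more compounds than this note shows. Statements on the series, on what has been measured and on what is new or still open speak of the compounds shown alone.

The series shares one core, shown first as compound 1 `CCOC(=O)C1=C(C)N/C(=C/c2cc(C)n(-c3ccc(Br)cc3)c2C)C1=O`, which in a physicochemical assay for lipophilicity, read by HPLC, at pH 7.4 (on this read-out higher numbers stand for higher lipophilicity and lower numbers for lower lipophilicity), gives 3.4. Compound 2 `CCOC(=O)C1=C(C)N/C(=C/c2cc(C)n(-c3ccc(S(=O)(=O)C(F)(F)F)cc3)c2C)C1=O` carries a (trifluoromethyl)sulfonyl group on the pendant aromatic ring, but in this assay compound 2 gives "not determined" (no result reported), so it stands without a number. Compound 3 `CCOC(=O)C1=C(C)N/C(=C/c2cc(C)n(-c3ccc(CN4CCCCC4)cc3)c2C)C1=O` is related to compound 2 by one change: (piperidin-1-yl)methyl in place of (trifluoromethyl)sulfonyl on an aromatic carbon. Between compound 2 and compound 3 no measured step exists, so the direction of the change rests on the values of the other compounds alone. A move towards a (piperidin-1-yl)methyl group is expected to lower the read-out in this assay by a sizeable step, clearly beyond the scatter, and well below the value of compound 1. For compound 3 the expected result in this assay is estimated at 1.8, in a range from 1 to 2.6.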

Compound 3, distribution coefficient: 8.5
Compound 3: the middle estimate sits 6.70 log units below what was measured, outside the stated range (above it).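

For the compounds shown here, with only compound 1 carrying a number, this position had offered no step until now. In this assay, (piperidin-1-yl)methyl in place of bromo on an aromatic carbon gives a number 5.10 log units higher from compound 1 to compound 3 (beyond the scatter), so the group at this place can move the read-out strongly and upward. The step from compound 2 cannot be read, as compound 2 has no number, and nothing shown here offers an explanation for the rise.

From the compounds shown here alone, it remains open whether a morpholine, a dimethylamino group or a carboxylic acid on the same carbon would move the read-out in the same direction. Also open, going by these compounds, is whether a piperidine joined directly to the ring, without the methyl link, would give a similar value.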